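A few compounds are considered here, and "the series" means these few. Any claim that something is new, unique, unknown or untested is made for them only; others in the source may bear on it.

Three compounds share a lactone core carrying two benzyloxy groups, and each was tested in a functional assay on HeLa cells (Homo sapiens) for inhibition, read by MTT assay, with a stated time of 72 h; on this read-out lower numbers stand for stronger inhibition and higher numbers for weaker inhibition. Compound 1 `Nc1ncn(CCC2(N)OC(=O)C(OCc3ccccc3)=C2OCc2ccccc2)c(=O)n1` joins the core, through a short saturated chain, to a six-membered aromatic ring bearing three nitrogen atoms. In this assay compound 1 gives > 100000 nM, which is a limit of the assay rather than a measured number (the limit of > 100000 nM in this assay, at which 1 of the 3 values shown sits). Compound 2 `Nc1ncn(C/C=C2\OC(=O)C(OCc3ccccc3)=C2OCc2ccccc2)c(=O)n1` carries the same aromatic ring but links it through a chain holding a double bond, and in this assay compound 2 gives 5910 nM. Compound 3 `O=C1O[C@H]([C@@H](O)Cn2ccc(NC(=O)c3ccccc3)nc2=O)C(OCc2ccccc2)=C1OCc1ccccc1` has a hydroxyl-bearing chain and a benzoyl-protected ring, and in this assay compound 3 gives 35900 nM.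

The new compound 4 `Nc1ccn(CCC2(N)OC(=O)C(OCc3ccccc3)=C2OCc2ccccc2)c(=O)n1` differs from compound 1 in one place (a group of 8 heavy atoms (4 carbon, 3 nitrogen, 1 oxygen; one six-membered aromatic ring with 2 hetero atoms) in place of a group of 8 heavy atoms (3 carbon, 4 nitrogen, 1 oxygen; one six-membered aromatic ring with 3 hetero atoms), on a saturated chain carbon, two bonds along the chain from a saturated ring carbon). Within the data shown here, no pair of measured compounds shows this exact change, so its size is unknown. Given that compound 1 itself reaches only the limit > 100000 nM, compound 4 is expected to stay weak as well, with a step of a number no higher from compound 1 to compound 4 (the limit leaves the size open) not beyond the scatter. Compound 4 is estimated at 100000 nM, likely between 20000 nM and 500000 nM.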

Compound 4, half-maximal inhibitory concentration: > 100000 nM
Compound 4 was reported as a limit; the forecaster's own chance of this, stated with the estimate: 60%; the middle value sits exactly at the limit.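

Compound 1 and compound 4 are both reported only as limits in this assay, so no step between them can be read: the limit of > 100000 nM in this assay, at which 2 of the 4 values shown sit.

The compounds shown leave open whether the group with 2 ring hetero atoms and the group with 3 differ in inhibition at all on this saturated chain.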